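This account rests on a few compounds, and the source may have more. Where it says the series, first, only, none or still open, it means among the compounds named here.

Compound 1 `O=C(NC1CCCCCC1)c1c(-c2ccccc2)c(Br)cn(Cc2ccc(F)cc2)c1=O` gives 3000 nM in an assay on HEK293 cells for inhibition of Monoacylglycerol lipase ABHD6 (Homo sapiens), with stated times of 30 min and 5 min (on this read-out lower numbers stand for stronger inhibition and higher numbers for weaker inhibition), the higher of the two numbers shown on this core family. Compound 3 `Cc1c(Br)cnc(OCc2ccc(F)cc2)c1C(=O)NC1CCCCCC1` gives 530 nM in this assay, beyond the scatter below compound 1. Compound 2 `COc1ccc(-c2c(Br)cn(Cc3ccc(F)cc3)c(=O)c2C(=O)NC2CCCCCC2)cc1` reaches only the limit of this assay, > 10000 nM. Within the data shown here, the one measured step within this set, an at least 3.3-fold higher number from compound 1 to compound 2 (0.52 log units; beyond the scatter), puts methoxy onto the phenyl group and runs to the limit (the limit of > 10000 nM in this assay, at which 1 of the 3 values shown sits); its size is therefore known only as a bound.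

Compound 4 `O=C(NC1CCCCCC1)c1c(-c2ccccc2)c(-c2ccccc2)cn(Cc2ccc(F)cc2)c1=O` differs from compound 1 in one place: phenyl in place of bromo on an aromatic carbon. Among the measured compounds shown here, no measured step touches this position, so the step of an at least 3.3-fold higher number from compound 1 to compound 2 (0.52 log units; beyond the scatter) bears on it only indirectly, as a sign that enlarging compound 1 in this region did not help. Compound 4 is therefore expected to land near or somewhat weaker than compound 1, with wide uncertainty, the expected step being a 1.5-fold higher number from compound 1 to compound 4 (0.18 log units; within the scatter). For compound 4 the estimate in this assay is 4500 nM, within 800 nM to 20000 nM.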

Compound 4, half-maximal inhibitory concentration: > 10000 nM
Compound 4 was reported as a limit (the forecaster's own chance of this, stated with the estimate: 30%); middle value at least 2.2-fold (0.34 log units) away from the limit.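

The bromo carbon, ortho to the phenyl group and two atoms from the ring nitrogen, now has a measured step of its own: an at least 3.3-fold higher number from compound 1 to compound 4 (0.52 log units; beyond the scatter). Phenyl in place of bromo therefore weakens inhibition beyond the scatter, and together with the methoxy step on the phenyl group of compound 1, this makes two places on the core of compound 1 where a larger group gave a weaker result. Compound 4 gives a limit of the assay and not a number, > 10000 nM, and the step is known only as a bound: the limit of > 10000 nM in this assay, at which 2 of the 4 values shown sit.

Whether the loss tracks the size of the entering group cannot be told from this single pair. On these data alone, what chloro, nitrile or an amine such as morpholine would do on this carbon remains open.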